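Cyano on the pyridine ring: expected effect on cytotoxicity

The source may hold more compounds than are shown below. What is called first, only, known or untested is meant among the compounds shown, and "the series" means these compounds.

Compound 1 `Cc1cnc(Nc2ccc(C#N)cc2)nc1Nc1c(F)cc(-c2cccnc2)cc1F` is tested in a toxicity assay on MT4 cells (Homo sapiens) for cytotoxicity, read by MTT assay, with a stated time of 5 days (on this read-out higher numbers stand for lower toxicity in this test and lower numbers for higher toxicity in this test), where compound 1 gives 1100 nM. Compound 2 `Cc1cnc(Nc2ccc(C#N)cc2)nc1Nc1c(F)cc(-c2cc(F)nc(F)c2)cc1F` shares the same core and gives 103000 nM in this assay. Within the data shown here, of these two numbers compound 1 holds the lowest, and its only neighbour is reached by a 94-fold higher number from compound 1 to compound 2 (1.97 log units; beyond the scatter), a step of substituting the ring at the same position.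

Compound 3 `Cc1cnc(Nc2ccc(C#N)cc2)nc1Nc1c(F)cc(-c2ccc(C#N)nc2)cc1F` differs from compound 1 by cyano in place of hydrogen on an aromatic carbon. Among the measured compounds shown here, the one comparison that bears on it is a 94-fold higher number from compound 1 to compound 2 (1.97 log units; beyond the scatter), which shows that changing groups on this pyridin-3-yl ring can move the number in this assay a long way upward. A single cyano is a smaller change than two fluorines with a shifted ring nitrogen, so an upward step of moderate size is expected for compound 3, namely a 7.3-fold higher number from compound 1 to compound 3 (0.86 log units; beyond the scatter). Compound 3 is therefore estimated at 8000 nM, within a range of 1500 nM to 50000 nM.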

Compound 3, half-maximal cytotoxic concentration: 62000 nM
Beside the measured number, compound 3's estimate is 7.8-fold (0.89 log units) below it; the measured number lies above the stated range.
By their numbers in this assay, from the lowest: compound 1; then compounds 3 and 2 (each within the scatter of the next).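

A single cyano in place of hydrogen, next to the ring nitrogen and para to a large group, is enough on its own to produce a large step in this assay (a 56-fold higher number from compound 1 to compound 3 (1.75 log units; beyond the scatter)), so on this read-out it goes with much lower toxicity in this test. The 6-cyanopyridin-3-yl and 2,6-difluoropyridin-4-yl rings cannot be told apart here (a 1.7-fold lower number from compound 2 to compound 3 (0.22 log units; within the scatter)), even though they differ in both their groups and the way the ring is attached. Nothing available here explains the size of the step from hydrogen to cyano.

The compounds shown leave open whether another single group at this place, such as an amine or a carboxylic acid, would give a step of similar size. They also leave open whether cyano would have the same effect elsewhere on this ring.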